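Furoxan-linked coumarin series: antiproliferative potency notes

The compounds below may be only part of what the source reports. "The series", "measured", "known", "first", "only" and "open" are said of these compounds alone.

Measured so far:
- compound 1, `Cc1c(Cc2ccc(F)cc2)c(=O)oc2cc(OCCOc3no[n+]([O-])c3S(=O)(=O)c3ccccc3)ccc12`: 2.8 nM
- compound 2, `COc1cc(OCCOc2no[n+]([O-])c2S(=O)(=O)c2ccccc2)ccc1C(=O)/C=C/c1ccccc1`: 17.8 nM

In a functional assay on HeLa cells (Homo sapiens) for antiproliferative activity, read by MTT assay, with a stated time of 48 h (on this read-out lower numbers stand for stronger inhibition and higher numbers for weaker inhibition), compound 1 gives 2.8 nM, the lowest of the two numbers in hand. Compound 2, built on a different core, gives 17.8 nM in this assay, and the gap between the two lies beyond the scatter, so compound 1 stands as the stronger inhibitor of the pair on these numbers alone. Among the compounds with values here, no pair of measured compounds differs in a single place, so no measured step is available to calibrate the change now under consideration.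

Compound 3, `CNS(=O)(=O)Nc1cccc(Cc2c(C)c3ccc(OCCOc4no[n+]([O-])c4S(=O)(=O)c4ccccc4)cc3oc2=O)c1`, keeps the core of compound 1 and differs from it in one place: 3-((methylsulfamoyl)amino)phenyl in place of 4-fluorophenyl on a saturated chain carbon bound to an aromatic carbon. Nothing in the measured data speaks to this change, so a small to moderate step in either direction, or none beyond the scatter, is possible; a shift toward a somewhat higher number is taken as the more likely outcome, since compound 1 already sits at the low end of what has been seen. Compound 3 is expected to give 5 nM in this assay, within 1.5 nM to 20 nM, which means an estimated step of a 1.8-fold higher number from compound 1 to compound 3 (0.25 log units; within the scatter).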

Compound 3, half-maximal inhibitory concentration: 15.4 nM
For compound 3 the middle estimate is 3.1-fold (0.49 log units) below the measured one; low and high end bracket the measured number.
By their numbers in this assay, from the lowest: compound 1; then compounds 3 and 2 (each within the scatter of the next).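

Working notes, position on the saturated chain carbon: in this assay the exchange of 4-fluorophenyl for 3-((methylsulfamoyl)amino)phenyl gives a 5.5-fold higher number from compound 1 to compound 3 (0.74 log units; beyond the scatter), the first measured step in this series and one beyond the scatter, so this position is not indifferent to its substituent. The step is modest, and compound 3 still gives 15.4 nM in this assay, so the position accepts the larger group, with its 12 heavy atoms and its hydrogen-bond donors and acceptors, while retaining activity at a lower level than compound 1. Nothing available explains the loss, and the change alters several features at once, so no single feature can be held responsible.

On these data alone, whether the fluorine, the methylsulfamoyl amino group or both set the size of this step stays open, as does how an unsubstituted phenyl, or a phenyl carrying an amine or a carboxylic acid, would compare on the shared core. Also open, as far as these compounds go, is whether the same exchange would give a step of similar size on a different core.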